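The source may report more compounds than this note shows. Statements on the series, on what has been measured and on what is new or still open speak of the compounds shown alone.

Compound 1: `CCCCc1nc(C(C)C)c(CC(=O)OCC(C)C)c(=O)n1Cc1ccc(-c2ccccc2-c2noc(=O)[nH]2)cc1` with 13.7%; compound 2: `CCCCc1nc(C)c(CC(=O)OC)c(=O)n1Cc1ccc(-c2ccccc2-c2noc(=O)[nH]2)cc1` with 47.1%.

In an ADME assay on microsomes from liver (Mus musculus) for metabolic stability, with a stated time of 30 min (on this read-out higher numbers stand for a more stable compound and lower numbers for a less stable compound), compound 2 gives 47.1%, the higher of the two numbers, and compound 1 gives 13.7%, a gap beyond the usual scatter. Compound 3, `CCCCc1nc(C)c(CC(=O)OCC(C)C)c(=O)n1Cc1ccc(-c2ccccc2-c2noc(=O)[nH]2)cc1`, has not been measured. It differs from compound 2 by isopropyl in place of hydrogen on a saturated chain carbon bound to an oxygen next to a carbonyl group; read one bond further out, methoxycarbonyl becomes isobutoxycarbonyl. Compound 1 also carries the isobutyl ester and gives 13.7%, so a drop beyond the scatter is expected. Compound 3 is estimated at 25%, between 10% and 45%, a change of a number 22.1 percentage points lower from compound 2 to compound 3 (beyond the scatter) in this assay.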

Compound 3, percent of the compound remaining: 7.7%
Beside the measured number, compound 3's estimate is 17.3 percentage points above it, outside the stated range (below it).
By their numbers in this assay, from the lowest: compounds 3 and 1 (each within the scatter of the next); then compound 2.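

In this assay, among these compounds, isopropyl in place of hydrogen on this saturated chain carbon, read as methoxycarbonyl becoming isobutoxycarbonyl, gives a number 39.4 percentage points lower from compound 2 to compound 3 (beyond the scatter) as the only change, so this one ester change is enough for a large step. Methyl in place of isopropyl on an aromatic carbon, with the isobutoxycarbonyl group kept, gives a number 6 percentage points lower from compound 1 to compound 3 (within the scatter) and so does not separate these two compounds. Nothing at hand explains either result. Going by these compounds, whether an ethyl ester or a carboxylic acid at this place would stay closer to compound 2 remains open. So does the effect of the aromatic carbon's isopropyl group alongside methoxycarbonyl.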